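A few compounds are considered here, and "the series" means these few. Any claim that something is new, unique, unknown or untested is made for them only; others in the source may bear on it.

Measured compounds:
Compound 1 `N=C(N)NCCC[C@H](NC(=O)CN(c1nc(Cl)nc2[nH]cnc12)C1CC1)C(=O)O`: 7.19%
Compound 2 `O=C(CN(c1nc(Cl)nc2[nH]cnc12)C1CC1)N[C@@H](CO)C(=O)O`: 18.8%

In a functional assay on the whole organism (Tail, strain ICR) with Mus musculus as the target, in the tail flick test, with a stated time of 150 min, at a dose of 25 umol/kg by the oral route (on this read-out higher numbers stand for a stronger effect at the one dose given and lower numbers for a weaker effect), compound 2 gives 18.8%, the higher of the two numbers at hand; its nearest neighbour is compound 1, and the step of a number 11.6 percentage points higher from compound 1 to compound 2 (beyond the scatter) lies beyond the scatter. Compound 3 `NC(=O)C[C@H](NC(=O)CN(c1nc(Cl)nc2[nH]cnc12)C1CC1)C(=O)O` is not yet measured. It differs from compound 2 by carbamoyl in place of hydroxy on a saturated chain carbon, two bonds along the chain from an amide-type nitrogen and a carbonyl carbon. Among the measured compounds shown here, only one measured step bears on this change: the step from compound 1 to compound 2 alters the same position of the chain, and it was modest, a number 11.6 percentage points higher from compound 1 to compound 2 (beyond the scatter). For the measured compounds named here, no measured pair shows what a carbamoyl group at that place does, so the direction is open. A step of at most modest size is therefore expected in this assay, and most likely none beyond the scatter, as a number 1.8 percentage points lower from compound 2 to compound 3 (within the scatter). Compound 3 is expected to give 17%, within a range from 5% to 32%.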

Compound 3, a percentage reported as activity, at one dose (the size of the read-out at that dose, not a potency): 7.51%
Beside the measured number, compound 3's estimate is 9.5 percentage points above it; measured number inside the range.
By their numbers in this assay, from the lowest: compounds 1 and 3 (each within the scatter of the next); then compound 2.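

In this assay, a group larger than hydroxy at this saturated chain carbon is now shown to matter even when the new group is small and uncharged: carbamoyl in place of hydroxy gives a number 11.3 percentage points lower from compound 2 to compound 3 (beyond the scatter). Replacing the whole chain at this carbon with the carbamoylmethyl chain gives a number 0.3 percentage points higher from compound 1 to compound 3 (within the scatter), so two quite different chains read alike, and among these three compounds only compound 2, with its hydroxymethyl chain, stands apart beyond the scatter. No measurement here explains why the hydroxymethyl chain stands apart. Still open, as far as these compounds go, is whether the hydroxy group itself is what counts, which a methyl group, an amine, a carboxylic acid or a longer chain ending in hydroxy at this place could test. These numbers also come from a single dose and time, so they say nothing about potency.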